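The source may report more compounds than this note shows. Statements on the series, on what has been measured and on what is new or still open speak of the compounds shown alone.

Among the compounds with values here, compound 2, with the structure `c1ccc2c(c1)CN[C@@H](CN(CCN1CCNCC1)[C@H]1CCCc3cccnc31)C2`, is one of two compounds measured so far in an ADME assay on microsomes from liver (Homo sapiens) for metabolic stability, read by LC-MS, with a stated time of 10 min, tested at 0.5 uM; a higher number here means that more of the compound is left, a lower number that less of the compound is left. In this assay compound 2 gives 96%. Within the data shown here, its only measured neighbour is compound 1, with the structure `c1ccc2c(c1)CN[C@@H](CN(CCCN1CCNCC1)[C@H]1CCCc3cccnc31)C2`, which in this assay gives 100%; the step of a number 4 percentage points lower from compound 1 to compound 2 (within the scatter) is within the usual scatter, so the two numbers are indistinguishable and both show the compounds remaining nearly untouched by the liver microsomes.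

Compound 3, with the structure `c1ccc2c(c1)CN[C@@H](CN(CC[C@H]1CCCNC1)[C@H]1CCCc3cccnc31)C2`, has not yet been measured. It differs from compound 2 by piperidin-3-yl in place of piperazin-1-yl on a saturated chain carbon, two bonds along the chain from an amine nitrogen. Among the measured compounds shown here, the single measured step bears on this only loosely: it changed the same chain region of the molecule but lengthened or shortened the chain rather than exchanging the ring, and it produced no change beyond the scatter. With nothing in the measured steps pointing to a shift, the step of a number 4 percentage points lower from compound 2 to compound 3 (within the scatter) is expected to stay within the scatter. Compound 3 is therefore expected to give 92% in this assay, within a range from 75% to 100%.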

Compound 3, percent of the compound remaining: 93%
Beside the measured number, compound 3's estimate is 1 percentage points below it; the measured number falls inside the stated range.
By their numbers in this assay, from the lowest: compounds 3, 2 and 1 (each within the scatter of the next).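

The earlier step altered only the chain length, whereas this result concerns the ring itself: in this assay, exchanging the piperazin-1-yl at the end of the chain for piperidin-3-yl gives a number 3 percentage points lower from compound 2 to compound 3 (within the scatter) even though the ring has 1 hetero atom instead of 2 and brings 1 defined stereocentre. The comparison with the longer-chain compound, which differs by piperidin-3-yl in place of (piperazin-1-yl)methyl, gives a number 7 percentage points lower from compound 1 to compound 3 (within the scatter) and so also cannot separate the two compounds. No supporting measurement is available to explain why these numbers lie so close together.

Both rings shown carry 1 hydrogen-bond donor, so it remains open whether morpholin-4-yl, which has a ring oxygen in place of that ring nitrogen, would give a number beyond the scatter at this place. From the compounds shown here alone, the opposite stereocentre of piperidin-3-yl, an open-chain amine and a carboxylic acid at the end of the chain also remain open.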